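Trifluoromethyl in place of bromo at the assay limit

The source may report more compounds than this note shows. Statements on the series, on what has been measured and on what is new or still open speak of the compounds shown alone.

In an ADME assay on HaCaT cells (Homo sapiens) for cytotoxicity, read by MTT assay, with a stated time of 48 h (a higher number here means a weaker inhibitor, a lower number a stronger inhibitor), compound 3 (`Clc1ccc(-c2nn(-c3ccccc3)cc2-c2nc3cc(Br)ccc3[nH]2)cc1`) sits at > 50000 nM as a limit and not a number. Compound 2 (`Clc1ccc(-c2nn(-c3ccccc3)cc2-c2nc3ccccc3[nH]2)cc1`) sits at > 50000 nM as a limit too. Among the compounds with values here, the one measured change in a single place is a step that the two limits leave unreadable from compound 2 to compound 3 and it gives no size to carry forward. Within the data shown here, compound 1 (`FC(F)(F)c1ccc2[nH]c(-c3cn(-c4ccccc4)nc3-c3ccccc3)nc2c1`) gives 37200 nM in this assay and is the only compound here with a true number.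

Compound 4 (`FC(F)(F)c1ccc2[nH]c(-c3cn(-c4ccccc4)nc3-c3ccc(Cl)cc3)nc2c1`) differs from compound 3 by trifluoromethyl in place of bromo on an aromatic carbon and shares that trifluoromethyl group with compound 1. Among the measured compounds shown here, no measured step shows what this swap does. The nearest guide is therefore compound 1 at 37200 nM with the same group, which points to a modest move toward a lower number, meaning a stronger inhibitor. The expected size is an at least 1.2-fold lower number from compound 3 to compound 4 (0.09 log units; that floor lies within the scatter) in this assay and it remains rough, since the starting point is only a limit. Compound 4 is estimated at 40000 nM with a range of 20000 nM to 60000 nM and it may also return only a limit.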

Compound 4, half-maximal inhibitory concentration: 41800 nM
The estimate for compound 4 lay 1.0-fold (0.02 log units) below the measured number, and the stated range covers the measured number.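

Within the data shown here, compound 4 gives the first readable steps at this position, where the earlier step from hydrogen to bromo could not be read. In this assay, trifluoromethyl in place of bromo on an aromatic carbon gives an at least 1.1-fold lower number from compound 3 to compound 4 (0.07 log units; that floor lies within the scatter) and the same group put where a hydrogen stood gives an at least 1.1-fold lower number from compound 2 to compound 4 (0.07 log units; that floor lies within the scatter), so trifluoromethyl here yields a true number, though both steps remain floors and not full sizes because the starting compounds stand at a limit of the assay: the limit of > 50000 nM in this assay, at which 2 of the 4 values shown sit. With trifluoromethyl held in place, adding the chloro group gives a 1.1-fold higher number from compound 1 to compound 4 (0.05 log units; within the scatter), so this pair shows no readable effect of the chloro change.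

The compounds shown leave open how trifluoromethyl and bromo truly compare at this position, since only a number for compound 3 could settle that. They also leave open whether a different group in the same place, such as an amine or a carboxylic acid, would move the number beyond the scatter.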